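The source may report more compounds than this note shows. Statements on the series, on what has been measured and on what is new or still open speak of the compounds shown alone.

Compound 1 `CNC(=O)c1cc(Oc2ccc(NC(=O)c3nn(-c4ccc(Br)cc4F)c(=O)cc3C)cc2F)ccn1` gives 9360 nM in a functional assay on MCF7 cells (Homo sapiens) for cytotoxicity, read by MTT assay, with a stated time of 72 h; a higher number here means a weaker inhibitor, a lower number a stronger inhibitor. Compound 3 `Cc1cc(=O)n(-c2ccccc2C(F)(F)F)nc1C(=O)Nc1ccc(Oc2ncnc3ccsc23)cc1` gives 5550 nM in this assay. Compound 2 `CNC(=O)c1cc(Oc2ccc(NC(=O)c3nn(-c4ccccc4F)c(=O)cc3C)cc2F)ccn1` reaches only > 40000 nM in this assay, which is a limit and not a number.

Compound 3 thus holds the lower of the two numbers, with compound 1 nearest and within the scatter. Among the measured compounds shown here, the one step measured on the aryl group attached to the same ring nitrogen, an at least 4.2-fold higher number from compound 1 to compound 2 (0.63 log units; beyond the scatter), took bromo away and weakened inhibition; its end point is a limit (the limit of > 40000 nM in this assay, at which 1 of the 3 values shown sits), so its full size is not known. Compound 4 `Cc1cc(=O)n(-c2cccc(F)c2)nc1C(=O)Nc1ccc(Oc2ncnc3ccsc23)cc1` differs from compound 3 by 3-fluorophenyl in place of 2-(trifluoromethyl)phenyl on an aromatic nitrogen. Because the step of an at least 4.2-fold higher number from compound 1 to compound 2 (0.63 log units; beyond the scatter) went toward a higher number when a halogen was lost, compound 4 is expected to move the same way, a 2.2-fold higher number from compound 3 to compound 4 (0.33 log units; beyond the scatter). Compound 4 is therefore estimated at 12000 nM, most likely between 4000 nM and 40000 nM.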

Compound 4, half-maximal inhibitory concentration: 6410 nM
Compound 4: middle estimate off by 1.9-fold (0.27 log units), on the high side, and the stated range covers the measured number.
By their numbers in this assay, from the lowest: compounds 3, 4 and 1 (each within the scatter of the next). At a limit, above all of these: compound 2.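

The step of a 1.2-fold higher number from compound 3 to compound 4 (0.06 log units; within the scatter) shows that, on this core, 3-fluorophenyl can stand on the ring nitrogen in place of 2-(trifluoromethyl)phenyl without a shift beyond the scatter in this assay. The group there can thus lose two fluorine atoms and the trifluoromethyl group without a measurable change, unlike the earlier loss of bromo on the other core. Nothing given here explains this result. Going by these compounds, whether an amine or a carboxylic acid on this phenyl ring would move the number stays open, as does the effect of bromo on this core.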